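Sulfonyl Group Swaps and Clearance in Human Liver Microsomes

A few compounds are considered here, and "the series" means these few. Any claim that something is new, unique, unknown or untested is made for them only; others in the source may bear on it.

Three compounds share one core and differ in the group on the sulfonyl sulfur. In an ADME assay on microsomes from liver (Homo sapiens) for pharmacokinetics, read by LC-MS, with a stated time of 60 min, tested at 1 uM (a higher number here means faster removal of the compound, a lower number slower removal), compound 1 (`O=C(NCc1ccc(S(=O)(=O)c2cncc(C(F)(F)F)c2)cc1)N1Cc2ccncc2C1`) gives 13 mL/min/kg, compound 2 (`CN1CCC(S(=O)(=O)c2ccc(CNC(=O)N3Cc4ccncc4C3)cc2)CC1`) gives 11 mL/min/kg and compound 3 (`CN1CCN(S(=O)(=O)c2ccc(CNC(=O)N3Cc4ccncc4C3)cc2)CC1`) gives 9 mL/min/kg. Compound 3 therefore stands within the scatter of both others, and the numbers do not rank it against them.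

Compound 4 (`O=C(NCc1ccc(S(=O)(=O)N2CCC(N3CCCC3)CC2)cc1)N1Cc2ccncc2C1`) carries 4-(pyrrolidin-1-yl)piperidin-1-yl in place of the 4-methylpiperazin-1-yl of compound 3 on the sulfonyl sulfur: 4-(pyrrolidin-1-yl)piperidin-1-yl in place of 4-methylpiperazin-1-yl on a sulfonyl sulfur.

Among the compounds with values here, three measured steps bear on this change, all at the same place. They are a 1.4-fold lower number from compound 1 to compound 3 (0.16 log units; within the scatter), a 1.2-fold lower number from compound 2 to compound 3 (0.09 log units; within the scatter) and a 1.2-fold lower number from compound 1 to compound 2 (0.07 log units; within the scatter). All three lie within the scatter, although the group that leaves compound 1 is quite unlike those in compound 2 and compound 3. Within the data shown here, none of the measured compounds carries the entering group, so this evidence is indirect. A step beyond the scatter in this assay is therefore not expected, and no firm direction can be given.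

The estimated step is a 1.3-fold higher number from compound 3 to compound 4 (0.12 log units; within the scatter). For compound 4 the expected value is 12 mL/min/kg, with an estimated range from 7 mL/min/kg to 22 mL/min/kg.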

Compound 4, clearance in the Homo sapiens assay: 6 mL/min/kg
Estimate against measurement, compound 4: 2.0-fold (0.30 log units) above, outside the stated range (below it).
By their numbers in the Homo sapiens assay, from the lowest: compounds 4, 3, 2 and 1 (each within the scatter of the next, the first and the last beyond it).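

Within the data shown here, in the Homo sapiens assay, the entering 4-(pyrrolidin-1-yl)piperidin-1-yl gives a 1.5-fold lower number from compound 3 to compound 4 (0.18 log units; within the scatter) and a 1.8-fold lower number from compound 2 to compound 4 (0.26 log units; within the scatter), both printed as within the scatter, while a 2.2-fold lower number from compound 1 to compound 4 (0.34 log units; beyond the scatter) is the first step at this position to lie beyond it, and only modestly so. The sulfonyl sulfur therefore takes a group of 11 heavy atoms, against 7 in the 4-methylpiperazin-1-yl it replaces, without any step beyond the scatter from compound 2 or compound 3 in this clearance read-out. The same change is far from neutral elsewhere, and in a physicochemical assay for solubility, in phosphate buffer, with a stated time of 24 h, at pH 7.4, tested at 100 uM (a lower number here means a less soluble compound, a higher number a more soluble compound), it gives a large step that the clearance numbers gave no sign of: the measured solubility of compound 3, 160000 nM, and of compound 4, 6200 nM, a 26-fold lower number (1.41 log units; beyond the scatter).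

In the physicochemical assay compound 3 gives 160000 nM and compound 4 gives 6200 nM. The compounds shown leave open whether that step in solubility belongs to the pyrrolidine ring itself or to the larger group as a whole, a question that a dimethylamino group or a morpholine ring in place of the pyrrolidin-1-yl could help to separate. Among these compounds, with solubility values shown for only two compounds, no trend across this position can be drawn, and the place of compound 1 and compound 2 in that read-out stays unknown.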